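The source may report more compounds than this note shows. Statements on the series, on what has been measured and on what is new or still open speak of the compounds shown alone.

Measured so far in an ADME assay, in phosphate buffer, at 28 degrees C, at pH 7.0; on this read-out higher numbers stand for a longer-lived compound and lower numbers for a shorter-lived compound:
compound 1 `Cn1cc([C@@H](O)[C@H]2C(=O)N3C(C(=O)O)=C(C(C)(C)C)O[C@H]23)nn1` gives 6.8 h;
compound 2 `CC(C)(C)C1=C(C(=O)O)N2C(=O)[C@H]([C@H](O)CCc3ccc(O)cc3)[C@H]2O1` gives 24.6 h;
compound 3 `CC(C)(C)OC(=O)[C@H](O)[C@H]1C(=O)N2C(C(=O)O)=C(C(C)(C)C)O[C@H]12` gives 10.7 h.

On these numbers compound 3 stands second of the three: its result lies within the scatter of compound 1 and beyond the scatter below compound 2. Compound 4 `CC(C)(C)C1=C(C(=O)O)N2C(=O)[C@H]([C@@H](O)CCc3ccncc3)[C@H]2O1` differs from compound 3 in one place: 2-(pyridin-4-yl)ethyl in place of tert-butoxycarbonyl on a saturated chain carbon bound to an oxygen on a saturated carbon and a saturated ring carbon. Compound 2, at 24.6 h, is the closest measured comparison for a group of this kind at that position, and it gives the highest number of the three. The step from compound 3 to compound 4 is therefore expected to be a modest rise in this assay, around the edge of the scatter, namely a 1.7-fold higher number from compound 3 to compound 4 (0.23 log units; within the scatter). Compound 4 is expected to give about 18 h, with a likely range from 8 h to 36 h.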

Compound 4, half-life: 15.8 h
Estimate against measurement, compound 4: 1.1-fold (0.06 log units) above, within the range that was stated.
By their numbers in this assay, from the lowest: compounds 1, 3, 4 and 2 (each within the scatter of the next, the first and the last beyond it).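

In this assay, the only one-place comparison shown at this saturated chain carbon gives a 1.5-fold higher number from compound 3 to compound 4 (0.17 log units; within the scatter). Exchanging tert-butoxycarbonyl, which has no ring, for 2-(pyridin-4-yl)ethyl, which carries a six-membered aromatic ring, therefore leaves the half-life within the usual scatter, so this pair shows no clear effect of even so large a change. No measurement shown here accounts for this result.

From the compounds shown here alone, it remains open whether an amine, a carboxylic acid or a longer chain in place of 2-(pyridin-4-yl)ethyl would move the half-life beyond the scatter.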